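The compounds below may be only part of what the source reports. "The series", "measured", "known", "first", "only" and "open" are said of these compounds alone.

Three compounds of this series have been measured in a functional assay on BMMC cells (Mus musculus, strain C57BL/6) for inhibition, with stated times of 5 days and 48 h; a lower number here means a stronger inhibitor, a higher number a weaker inhibitor:

Compound 1, `C=C1CC[C@@H]2[C@](C)(CNCc3ccccc3)[C@H](O)CC[C@@]2(C)[C@@H]1/C=C/C1=CCOC1=O`: 960 nM
Compound 2, `C=C1CC[C@@H]2[C@](C)(CNCc3ccc(C)cc3)[C@H](O)CC[C@@]2(C)[C@@H]1/C=C/C1=CCOC1=O`: 740 nM
Compound 3, `C=C1CC[C@@H]2[C@](C)(CNCc3ccc(O)c(O)c3)[C@H](O)CC[C@@]2(C)[C@@H]1/C=C/C1=CCOC1=O`: 9440 nM

Compound 3 gives the highest number of the three, set apart from the others by the steps of a 9.8-fold higher number from compound 1 to compound 3 (0.99 log units; beyond the scatter) and a 13-fold higher number from compound 2 to compound 3 (1.11 log units; beyond the scatter). The unmeasured compound 4, `C=C1CC[C@@H]2[C@](C)(CNCc3ccc(F)cc3)[C@H](O)CC[C@@]2(C)[C@@H]1/C=C/C1=CCOC1=O`, differs from compound 3 in one place: 4-fluorophenyl in place of 3,4-dihydroxyphenyl on a saturated chain carbon bound to an amine nitrogen. This change reverses the kind of replacement seen in a 9.8-fold higher number from compound 1 to compound 3 (0.99 log units; beyond the scatter) and a 13-fold higher number from compound 2 to compound 3 (1.11 log units; beyond the scatter), while a 1.3-fold lower number from compound 1 to compound 2 (0.11 log units; within the scatter) shows that a small group on the ring hardly moves the number. Compound 4 is therefore expected to fall back to the earlier level, with an estimated step of an 11-fold lower number from compound 3 to compound 4 (1.05 log units; beyond the scatter). For compound 4 the expected value in this assay is 850 nM, ranging from 400 nM to 2000 nM.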

Compound 4, half-maximal inhibitory concentration: 350 nM
The estimate for compound 4 lay 2.4-fold (0.39 log units) above the measured number; the measured number lies below the stated range.
By their numbers in this assay, from the lowest: compound 4; then compounds 2 and 1 (each within the scatter of the next); then compound 3.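

In this assay, for the compounds shown here, 4-fluorophenyl in place of 3,4-dihydroxyphenyl gives a 27-fold lower number from compound 3 to compound 4 (1.43 log units; beyond the scatter), and this goes further than recovering the level of the earlier compounds. A group on this ring can therefore lower the number beyond the scatter, with a 2.7-fold lower number from compound 1 to compound 4 (0.44 log units; beyond the scatter) and a 2.1-fold lower number from compound 2 to compound 4 (0.33 log units; beyond the scatter), whereas methyl in place of hydrogen had stayed within it. Nothing available explains why fluoro behaves differently from methyl here.

Going by these compounds, whether chloro or methoxy at the same ring position would match fluoro remains open. On these data alone, it is also open whether a single hydroxyl group would raise the number as far as the two in compound 3 do.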